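Working notes on cytotoxicity across three analogues and one candidate

The source may report more compounds than this note shows. Statements on the series, on what has been measured and on what is new or still open speak of the compounds shown alone.

Compound 1 `Nc1nc(N2CCCC2)c2ncn(/C=C3/CC3(CO)CO)c2n1` is measured in an ADME assay on HFF cells (Homo sapiens) for cytotoxicity, with a stated time of 8 days; a lower number here means that less compound is tolerated, a higher number that more compound is tolerated. In this assay compound 1 gives > 300000 nM, which is a limit of the assay and not a number. Compound 2 `CCCCCOc1nc(N)nc2c1ncn2/C=C1/CC1(CO)CO` gives 259000 nM. Compound 3 `CCCCNc1nc(N)nc2c1ncn2/C=C1/CC1(CO)CO` gives > 300000 nM, again a limit of the assay. The series is bounded by the limit of > 300000 nM in this assay, at which 2 of the 3 values shown sit. The steps of an at least 1.1-fold lower number from compound 1 to compound 2 (0.06 log units; that floor lies within the scatter) and an at least 1.1-fold higher number from compound 2 to compound 3 (0.06 log units; that floor lies within the scatter) stay within the scatter, and a step that the two limits leave unreadable from compound 1 to compound 3 cannot be read. Compound 4 `Nc1nc(SCc2ccccc2)c2ncn(/C=C3/CC3(CO)CO)c2n1` is not yet measured; it differs from compound 1 by benzylsulfanyl in place of pyrrolidin-1-yl on an aromatic carbon. For the measured compounds named here, none of the measured steps exchanges pyrrolidin-1-yl for benzylsulfanyl, so they bear on this change only by showing that replacing pyrrolidin-1-yl left the read-out near its ceiling. Compound 4 is therefore expected to give 200000 nM, between 60000 nM and 300000 nM. The expected step of an at least 1.5-fold lower number from compound 1 to compound 4 (0.17 log units; that floor lies within the scatter) would not exceed the scatter.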

Compound 4, half-maximal cytotoxic concentration: > 300000 nM
Compound 4 was reported as a limit (the forecaster's own chance of this, stated with the estimate: 45%); at least 1.5-fold (0.17 log units) between middle value and limit.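

In this assay compound 4 gives > 300000 nM, a limit of the assay and not a number, so benzylsulfanyl, with its six-membered aromatic ring of carbon only, also leaves the read-out at the limit on this aromatic carbon. For the compounds shown here, the only readable step is an at least 1.1-fold higher number from compound 2 to compound 4 (0.06 log units; that floor lies within the scatter); the steps from compound 1 and compound 3 to compound 4 cannot be read. The series remains bounded by the same ceiling: the limit of > 300000 nM in this assay, at which 3 of the 4 values shown sit.

No order among pyrrolidin-1-yl, butylamino and benzylsulfanyl can be given. On these data alone, whether a carboxylic acid or a longer chain on this carbon would bring the read-out off the limit stays open.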